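Positional Isomer Swap in a Piperidine Acetamide Series

The source may report more compounds than this note shows. Statements on the series, on what has been measured and on what is new or still open speak of the compounds shown alone.

Compound 1 `Cc1cc(NC(=O)CN2CCC(c3cccc[n+]3[O-])CC2)ccc1F` gives 75% in a functional assay on HEK293 cells for agonist activity at D(4) dopamine receptor (Homo sapiens), read by FLIPR; on this read-out lower numbers stand for smaller maximal responses and higher numbers for larger maximal responses.
Compound 2 `Cc1cccc(Cl)c1NC(=O)CN1CCC(c2ccccn2)CC1` gives 70% in this assay.
Compound 3 `O=C(CN1CCC(c2cccc[n+]2[O-])CC1)Nc1cccc(-c2ccccc2)c1` gives 75% in this assay.

Compound 1 stands level with compound 3 at the digits shown, the two together the highest of the three numbers; compound 2 sits five points lower, which is within the scatter, so no order among the three can be claimed.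

Compound 4 `Cc1cc(F)ccc1NC(=O)CN1CCC(c2cccc[n+]2[O-])CC1` is the next case. It differs from compound 1 in one place: 4-fluoro-2-methylphenyl in place of 4-fluoro-3-methylphenyl on an amide-type nitrogen. Going by the values given here, no pair of measured compounds separated by a single change is available, so the size of this step cannot be read from the data. With all three measured values close together, the expectation is for no step beyond the scatter. Compound 4 is estimated at 72%, range 55% to 88%, an expected step of a number 3 percentage points lower from compound 1 to compound 4 (within the scatter).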

Compound 4, largest response reached (reported as efficacy), in percent of the reference or control that the assay uses: 84%
Compound 4: the middle estimate sits 12 percentage points below what was measured; the measured number falls inside the stated range.
By their numbers in this assay, from the lowest: compounds 2, 1, 3 and 4 (each within the scatter of the next, the first and the last beyond it).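

Going by these compounds alone, the swap of 4-fluoro-3-methylphenyl for 4-fluoro-2-methylphenyl on an amide-type nitrogen gives a number 9 percentage points higher from compound 1 to compound 4 (within the scatter) in this assay and is the first single-place step. It shows that joining the same atoms differently on this aryl group leaves the maximal response within the scatter. No measurement on hand explains this step. The compounds shown leave open whether an amine or a carboxylic acid on this aryl group would shift the response beyond the scatter. From the compounds shown here alone, whether this step holds on other parts of the core also remains open.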